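A few compounds are considered here, and "the series" means these few. Any claim that something is new, unique, unknown or untested is made for them only; others in the source may bear on it.

In an assay on BHK21 (C13) cells (Mesocricetus auratus) for inhibition of thymidine kinase, cytosolic (Cricetulus griseus), using Lineweaver-Burk analysis (on this read-out higher numbers stand for weaker inhibition and lower numbers for stronger inhibition), compound 1, `CC(=O)NC[C@H]1O[C@@H](n2cc(C)c(=O)[nH]c2=O)C[C@@H]1O`, gives 6500000 nM, and compound 2, `Cc1cn([C@H]2C[C@H](O)[C@@H](CSCCO)O2)c(=O)[nH]c1=O`, gives 800000 nM. Among the compounds with values here, compound 2 therefore stands at the lowest of the two numbers measured so far, the only step in the set being an 8.1-fold lower number from compound 1 to compound 2 (0.91 log units; beyond the scatter), a change of (2-hydroxyethyl)sulfanyl in place of acetamido on a saturated chain carbon bound to a saturated ring carbon. Compound 3, `Cc1cn([C@H]2C[C@H](O)[C@@H](CSCCCC(=O)O)O2)c(=O)[nH]c1=O`, keeps the sulfur chain of compound 2 and alters its end: carboxymethyl in place of hydroxy on a saturated chain carbon, two bonds along the chain from a sulfur. Within the data shown here, no measured step touches this part of the chain, so the earlier step does not bear on it directly and gives no direction to expect. In this assay compound 3 is therefore expected to land close to compound 2, with a step of a 1.3-fold higher number from compound 2 to compound 3 (0.10 log units; within the scatter) that need not exceed the scatter. The estimate for compound 3 in this assay is 1000000 nM, in a range from 200000 nM to 5000000 nM.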

Compound 3, inhibition constant: 1200000 nM
The estimate for compound 3 lay 1.2-fold (0.08 log units) below the measured number; the measured number falls inside the stated range.
By their numbers in this assay, from the lowest: compounds 2 and 3 (each within the scatter of the next); then compound 1.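

In this assay the chain end can go from hydroxy to the larger carboxymethyl with a 1.5-fold higher number from compound 2 to compound 3 (0.18 log units; within the scatter), so at this position the two ends cannot be told apart. What compound 2 alone could not show is that the lower number on leaving acetamido is not tied to a hydroxy chain end: the sulfur chain ending in a carboxylic acid also gives a 5.4-fold lower number from compound 1 to compound 3 (0.73 log units; beyond the scatter). Nothing shown gives a reason for these numbers.

From the compounds shown here alone, it remains open whether an amine at the chain end, or a much longer chain, would also leave the number within the scatter of compound 2. Within the data shown here, the part played by the sulfur also stays open, since no compound here has an oxygen atom in its place.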